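A few compounds are considered here, and "the series" means these few. Any claim that something is new, unique, unknown or untested is made for them only; others in the source may bear on it.

Working notes on the series. The shared core of compound 1 `O=C(/C=C\Nc1ccc(Cl)cc1)c1cn(-c2ccccc2)nc1-c1ccccc1` carries a chloro group; in a functional assay on PC-3 cells (Homo sapiens) for antiproliferative activity, read by MTT assay, with a stated time of 48 h (a higher number here means a weaker inhibitor, a lower number a stronger inhibitor), compound 1 gives 5200 nM. Compound 2 `O=C(/C=C\Nc1ccc(C(F)(F)F)cc1)c1cn(-c2ccccc2)nc1-c1ccccc1` has trifluoromethyl in its place; in this assay compound 2 reaches only the limit of the assay, > 50000 nM, and no number is known. Compound 3 `COc1ccc(N/C=C\C(=O)c2cn(-c3ccccc3)nc2-c2ccccc2)cc1` has methoxy there; in this assay compound 3 gives 6400 nM. Within the data shown here, of the two numbers known, compound 3 has the highest, with compound 1 nearest: a 1.2-fold higher number from compound 1 to compound 3 (0.09 log units; within the scatter), within the scatter, so no order between them is claimed; the third value is a limit (the limit of > 50000 nM in this assay, at which 1 of the 3 values shown sits). The other steps are larger: an at least 9.6-fold higher number from compound 1 to compound 2 (0.98 log units; beyond the scatter) and an at least 7.8-fold lower number from compound 2 to compound 3 (0.89 log units; beyond the scatter).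

Compound 4 `COc1ccc(N/C=C\C(=O)c2cn(-c3ccccc3)nc2-c2ccc(Cl)cc2)cc1` differs from compound 3 by chloro in place of hydrogen on an aromatic carbon. Among the measured compounds shown here, none of the measured steps touches this position; all three exchange chloro, trifluoromethyl and methoxy among themselves. There is thus no basis for a step beyond the scatter in this assay. Compound 4 is expected to give 6000 nM, range 2000 nM to 20000 nM. The expected step of a 1.1-fold lower number from compound 3 to compound 4 (0.03 log units; within the scatter) is estimated to lie within the scatter.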

Compound 4, half-maximal inhibitory concentration: 10700 nM
Compound 4: the middle estimate sits 1.8-fold (0.25 log units) below what was measured, and the stated range covers the measured number.
By their numbers in this assay, from the lowest: compounds 1, 3 and 4 (each within the scatter of the next, the first and the last beyond it). At a limit, above all of these: compound 2.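

Phenyl to 4-chlorophenyl is the first change in the series at this position, on an aromatic carbon para to a large group; the earlier steps all exchanged groups at another place. In this assay, the step is a 1.7-fold higher number from compound 3 to compound 4 (0.22 log units; within the scatter), so with methoxy held at the other place, chloro in place of hydrogen here gives no difference that can be told from the scatter. Nothing at hand bears on this step or offers a cause for it.

The compounds shown leave open whether this position stays as flat with an amine, a carboxylic acid or a longer chain in place of chloro. They also leave open whether chloro here gives the same result when the other place carries chloro or trifluoromethyl instead of methoxy.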